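Methyl in place of acetyl on a sulfur

This account rests on a few compounds, and the source may have more. Where it says the series, first, only, none or still open, it means among the compounds named here.

Two compounds have been measured so far in a functional assay on HL-60 cells (Homo sapiens) for inhibition, read by MTT assay, with a stated time of 2 days; on this read-out lower numbers stand for stronger inhibition and higher numbers for weaker inhibition:
compound 1, `COc1c(O)c(C)c(C/C=C(\C)CCCCCCc2ccccc2)oc1=O`, which gives 6200 nM;
compound 2, `COc1c(C)c(CCCCCCCCCCSC(C)=O)oc(=O)c1OC`, which gives 14600 nM.

Compound 2 stands at the highest of these two numbers, meaning the weaker inhibition of the pair; the gap to its nearest neighbour, compound 1, lies beyond the usual scatter. For the measured compounds named here, compound 1 and compound 2 differ in several places at once, so no single step between measured compounds is available to guide expectations.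

Compound 3, `COc1c(C)c(CCCCCCCCCCSC)oc(=O)c1OC`, has not yet been measured. It differs from compound 2 in one place only: methyl in place of acetyl on a sulfur. With nothing measured that isolates this change, the expected step of a 1.1-fold lower number from compound 2 to compound 3 (0.05 log units; within the scatter) is taken as no larger than the scatter, in no particular direction. Compound 3 is therefore estimated at about 13000 nM, with a range from 4500 nM to 40000 nM.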

Compound 3, half-maximal inhibitory concentration: 10800 nM
For compound 3 the middle estimate is 1.2-fold (0.08 log units) above the measured one; the measured number falls inside the stated range.
By their numbers in this assay, from the lowest: compounds 1, 3 and 2 (each within the scatter of the next, the first and the last beyond it).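

In this assay, exchanging the acetyl on the sulfur for a methyl gives a 1.4-fold lower number from compound 2 to compound 3 (0.13 log units; within the scatter), so compound 2 and compound 3 cannot be told apart on this read-out. For the compounds shown here, this is the first measured step that isolates a single place, and it shows that inhibition on this read-out stays within the scatter when the acetyl, with its double bond and hydrogen-bond acceptor, is gone from this sulfur. No supporting measurement is available to explain this outcome.

As far as these compounds go, it remains open whether a larger replacement on this sulfur, such as a benzyl group or a chain ending in a carboxylic acid or an amine, would also leave the number in place. From the compounds shown here alone, it is also open whether a sulfone, or an oxygen in place of the sulfur, would behave in the same way.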